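The source may report more compounds than this note shows. Statements on the series, on what has been measured and on what is new or still open speak of the compounds shown alone.

Three ureas sharing a common core have been measured in a functional assay on HepG2 cells (Homo sapiens) for antiproliferative activity, read by MTT assay, with a stated time of 48 h; a higher number here means a weaker inhibitor, a lower number a stronger inhibitor. Compound 1 `O=C(Nc1cccc(CNc2nccnc2Cl)c1)NC1CCCC1` gives 18400 nM. Compound 2 `Cc1ccccc1NC(=O)Nc1cccc(CNc2nccnc2Cl)c1` gives 15300 nM, and compound 3 `O=C(Nc1cccc(CNc2nccnc2Cl)c1)Nc1ccc(Cl)cc1Cl` gives 7230 nM. Compound 3 has the lowest number of the three: the step of a 2.5-fold lower number from compound 1 to compound 3 (0.41 log units; beyond the scatter) and the step of a 2.1-fold lower number from compound 2 to compound 3 (0.33 log units; beyond the scatter) both reach beyond the scatter, while the step of a 1.2-fold lower number from compound 1 to compound 2 (0.08 log units; within the scatter) does not. The next compound, compound 4 `O=C(Nc1cccc(CNc2nccnc2Cl)c1)Nc1ccc(F)c(Cl)c1`, keeps the core and alters only the group on the amide-type nitrogen: 3-chloro-4-fluorophenyl in place of 2,4-dichlorophenyl on an amide-type nitrogen. Going by the values given here, no measured step exchanges one halogen-bearing phenyl for another, so the measured steps bear on it only indirectly. The two steps that put 2,4-dichlorophenyl in place of cyclopentyl or of 2-methylphenyl were modest, and compound 4 keeps a phenyl carrying halogens in the same place, so the number for compound 4 is expected to stay close to that of compound 3, with a step of a 1.0-fold higher number from compound 3 to compound 4 (0.02 log units; within the scatter) that is not expected to go beyond the scatter. Compound 4 is therefore estimated at 7500 nM in this assay, within a range from 3000 nM to 18000 nM.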

Compound 4, half-maximal inhibitory concentration: 6750 nM
The estimate for compound 4 lay 1.1-fold (0.05 log units) above the measured number; measured number inside the range.
By their numbers in this assay, from the lowest: compounds 4 and 3 (each within the scatter of the next); then compounds 2 and 1 (each within the scatter of the next).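

In this assay, going by these compounds alone, the step in which 3-chloro-4-fluorophenyl takes the place of 2,4-dichlorophenyl on the amide-type nitrogen is the first measured exchange of one halogen-bearing phenyl for another, and at a 1.1-fold lower number from compound 3 to compound 4 (0.03 log units; within the scatter) it stays within the scatter, so these two halogen patterns cannot be told apart here. The second halogen pattern also stands apart from the two groups without halogens, with a 2.3-fold lower number from compound 2 to compound 4 (0.36 log units; beyond the scatter) and a 2.7-fold lower number from compound 1 to compound 4 (0.44 log units; beyond the scatter) both beyond the scatter though modest, so among these four compounds, compound 3 and compound 4 both have lower numbers than compound 1 and compound 2, and none of the four goes against this. Nothing available on these compounds offers an explanation for this pattern.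

What the compounds shown leave open is whether halogens are needed at all on this phenyl, since an unsubstituted phenyl or one carrying a single fluorine would test that directly. Also open, on these data alone, is how the number would respond to quite different groups on this nitrogen, such as a pyridine ring, a carboxylic acid, an amine or a longer alkyl chain.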